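The source may report more compounds than this note shows. Statements on the series, on what has been measured and on what is new or still open speak of the compounds shown alone.

Measured compounds in a functional assay on HCT-116 cells (Homo sapiens) for inhibition; on this read-out higher numbers stand for weaker inhibition and lower numbers for stronger inhibition:
compound 1 `CCNC(=O)c1noc(-c2cc(C(C)C)c(O)cc2O)c1-c1cc(CN(C)C)no1` gives 92 nM
compound 3 `CCNC(=O)c1noc(-c2cc(C(C)C)c(O)cc2O)c1-c1cc(C(N)=O)no1` gives 79 nM
compound 2 `CCNC(=O)c1noc(-c2cc(C(C)C)c(O)cc2O)c1-c1cc(C(=O)O)no1` gives "not determined" (no result reported) in this assay

On the numbers at hand, compound 3 carries the lowest of the two values, with compound 1 its nearest entry; the gap between them is within the usual scatter, so no order between the two can be claimed. Within the data shown here, the only measured step in the set is a 1.2-fold lower number from compound 1 to compound 3 (0.07 log units; within the scatter), corresponding to carbamoyl in place of (dimethylamino)methyl on an aromatic carbon.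

Compound 4 `CCNC(=O)c1noc(-c2cc(C(C)C)c(O)cc2O)c1-c1cnn(C(C)C)c1` differs from compound 3 by 1-isopropyl-1H-pyrazol-4-yl in place of 3-carbamoyl-1,2-oxazol-5-yl on an aromatic carbon.

Among the measured compounds shown here, no measured step covers an exchange of the ring itself; the single step available, which alters only the group carried on that ring, was within the scatter. The series therefore gives no basis to expect a step in this assay in either direction beyond the scatter, though the range must stay wide for a change that replaces the whole ring and removes the hydrogen-bond donor counted above. Compound 4 is expected to give about 120 nM in this assay, with a range from 40 nM to 400 nM. This estimate corresponds to an expected 1.5-fold higher number from compound 3 to compound 4 (0.18 log units; within the scatter).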

Compound 4, half-maximal inhibitory concentration: 21 nM
Beside the measured number, compound 4's estimate is 5.7-fold (0.76 log units) above it, and the stated range ends above it.
By their numbers in this assay, from the lowest: compound 4; then compounds 3 and 1 (each within the scatter of the next).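

In this assay, among these compounds, exchanging the whole ring at this position gives the first steps beyond the scatter: a 3.8-fold lower number from compound 3 to compound 4 (0.58 log units; beyond the scatter), and a 4.4-fold lower number from compound 1 to compound 4 (0.64 log units; beyond the scatter). The earlier exchange on the 1,2-oxazol-5-yl ring, a 1.2-fold lower number from compound 1 to compound 3 (0.07 log units; within the scatter), stayed within the scatter, so a difference at this position shows up only with the change to 1-isopropyl-1H-pyrazol-4-yl, which also leaves compound 4 with the lowest number of the measured compounds. The position therefore accepts a ring with no hydrogen-bond donor and with isopropyl in place of the earlier groups without any loss on this read-out, but no available measurement explains the lower number.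

The step changes the ring and its substituent together, so the shares of the pyrazole and of the isopropyl group cannot be separated, and a 1,2-oxazol-5-yl ring carrying isopropyl would be needed to divide them. As far as these compounds go, it also remains open how the read-out responds to other groups on the pyrazole nitrogen, such as methyl, cyclopropyl or a longer chain ending in an amine.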